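This account rests on a few compounds, and the source may have more. Where it says the series, first, only, none or still open, it means among the compounds named here.

Measured so far:
compound 1 `CC(=O)N1CCc2oc(=O)n(C(=O)NCCCCc3ccccc3)c2C1` — 293 nM
compound 2 `CC(C)CNC(=O)n1c(=O)oc2ccc(C3CCN(C)CC3)cc21` — 295 nM
compound 3 `CCC(C)NC(=O)n1c(=O)oc2cc(C3CCN(C)CC3)ccc21` — 2100 nM

All three numbers come from an assay on HEK293 cells for inhibition of acid ceramidase (Homo sapiens), read by fluorescence, with stated times of 10 min and 3 h; a higher number here means a weaker inhibitor, a lower number a stronger inhibitor. Compound 1 carries the lowest of the three; compound 2 sits within the scatter of it, while compound 3 lies beyond the scatter, giving a weaker number. Compound 4 `CN1CCc2oc(=O)n(C(=O)NCCCCc3ccccc3)c2C1` is not yet measured. It differs from compound 1 by methyl in place of acetyl on an amine nitrogen in a ring. Going by the values given here, no measured pair shows this exact exchange, so nothing direct can be read off for its size. The expected step is a 1.4-fold higher number from compound 1 to compound 4 (0.16 log units; within the scatter), small and toward a weaker inhibitor, or none beyond the scatter. Compound 4 is therefore estimated at 420 nM, with a range from 130 nM to 1400 nM.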

Compound 4, half-maximal inhibitory concentration: 516 nM
Compound 4: middle estimate off by 1.2-fold (0.09 log units), on the low side; the range from low to high includes it.
By their numbers in this assay, from the lowest: compounds 1, 2 and 4 (each within the scatter of the next); then compound 3.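

Methyl in place of acetyl on the amine nitrogen in the ring gives a 1.8-fold higher number from compound 1 to compound 4 (0.25 log units; within the scatter) in this assay, the first direct reading at this position. Removing the acetyl carbonyl, and with it the hydrogen-bond acceptor counted there, does not separate these two compounds in this assay. No measurement here accounts for the size of this step.

Going by these compounds, whether the unsubstituted ring amine or a benzyl group on this nitrogen would give a step beyond the scatter remains open. Also open, on these data alone, is whether a sulfonyl group or a carboxylic acid-bearing chain is accepted there.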